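From cyano to ethoxycarbonyl: a plasma half-life question

A few compounds are considered here, and "the series" means these few. Any claim that something is new, unique, unknown or untested is made for them only; others in the source may bear on it.

Measured so far in an ADME assay on a cell-free system (plasma, Homo sapiens) for metabolic stability, read by HPLC; a higher number here means that the compound lasts longer, a lower number that the compound disappears faster:
compound 1 `CN(/N=N/c1ccc(C#N)cc1)C(=O)CCc1ccc(O)cc1` gives 5.8 h
compound 2 `CN(/N=N/c1ccc(C#N)cc1)C(=O)CCCCc1ccc(O)cc1` gives 11.8 h

Of these two numbers, compound 2 holds the higher one. Compound 1 holds the lower one, and the gap lies just beyond the usual scatter of repeated measurements. Going by the values given here, with only two values, this says little about how the series behaves as a whole.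

The next compound, compound 3 `CCOC(=O)c1ccc(/N=N/N(C)C(=O)CCCCc2ccc(O)cc2)cc1`, keeps everything in compound 2 except one group (ethoxycarbonyl in place of cyano on an aromatic carbon). Ethoxycarbonyl stands in place of cyano on an aromatic carbon, para to a large group.

Among the compounds with values here, no measured pair shows what this swap does, so any forecast is a judgement and carries a wide range. Starting from compound 2 at 11.8 h in this assay, a downward step near the edge of the scatter is expected. The estimated move is a 2.1-fold lower number from compound 2 to compound 3 (0.33 log units; beyond the scatter) and it remains uncertain in both size and direction. For compound 3 an estimated half-life of 5.5 h is expected, with a likely range from 1.8 h to 14 h in this measurement.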

Compound 3, half-life: 26.3 h
Compound 3: middle estimate off by 4.8-fold (0.68 log units), on the low side; measured number above the stated range.
By their numbers in this assay, from the lowest: compound 1; then compound 2; then compound 3.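

In this assay, going by these compounds alone, putting ethoxycarbonyl in place of cyano on an aromatic carbon, para to a large group, gives a 2.2-fold higher number from compound 2 to compound 3 (0.35 log units; beyond the scatter) and so provides the first reading for a change at this position. The earlier pair differs only in the chain, so it could not show how this place responds. Here, the larger entering group, with five heavy atoms against two, comes with a longer half-life rather than a shorter one, although no measurement at hand explains the rise.

This single swap leaves open whether the longer half-life is particular to ethoxycarbonyl or would also appear with another group at this position, such as methoxycarbonyl, a carboxylic acid or an amide. It also leaves open whether the same swap would have a similar effect on the shorter chain of compound 1, since a change seen on one chain need not carry over to another.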